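The compounds below may be only part of what the source reports. "The series", "measured", "known", "first", "only" and "open" are said of these compounds alone.

Working notes on the series. Among the measured compounds shown here, compound 1 `CC1CCN(CCCSc2nc(C(F)(F)F)ccc2CNC(=O)C(C)c2ccc(NS(C)(=O)=O)c(F)c2)CC1` is the reference point: in an assay on CHO-K1 cells for antagonist activity at transient receptor potential cation channel subfamily V member 1 (Homo sapiens), read by FLIPR (on this read-out lower numbers stand for stronger inhibition and higher numbers for weaker inhibition), compound 1 gives 2.9 nM, the only number in the set so far. For the measured compounds named here, compound 2 `CC(C(=O)NCc1ccc(C(F)(F)F)nc1S(=O)(=O)C1CCCCC1)c1ccc(NS(C)(=O)=O)c(F)c1` carries a different sulfur-linked group and in this assay compound 2 is reported as "not active" (no number reported), without a number, so no step between the two measured compounds can be sized. Compound 3 `COc1ccc(CSc2nc(C(F)(F)F)ccc2CNC(=O)C(C)c2ccc(NS(C)(=O)=O)c(F)c2)cc1` is the next entry and has not yet been measured. Its difference from compound 1 is 4-methoxyphenyl in place of 2-(4-methylpiperidin-1-yl)ethyl on a saturated chain carbon bound to a sulfur. Without a measured step to lean on, the change from a chain with a nitrogen-containing saturated ring to an aromatic ring with a methoxy group is taken as a likely loss of potency, with the step from compound 1 to compound 3 expected to be a 10-fold higher number from compound 1 to compound 3 (1.01 log units; beyond the scatter) in this assay. The estimate for compound 3 in this assay is therefore 30 nM, with a range from 5 nM to 300 nM.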

Compound 3, inhibition constant: 2.3 nM
The estimate for compound 3 lay 13-fold (1.12 log units) above the measured number; measured number below the stated range.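

In this assay the exchange of 2-(4-methylpiperidin-1-yl)ethyl for 4-methoxyphenyl on a saturated chain carbon bound to a sulfur gives a 1.3-fold lower number from compound 1 to compound 3 (0.10 log units; within the scatter) and leaves the two compounds indistinguishable on this read-out. This position therefore accepts both a six-membered non-aromatic ring with a hetero atom and a six-membered aromatic ring of carbon only, and the ring nitrogen of compound 1 is not required for a number of this order. Nothing measured on either group accounts for this result.

Still open, going by these compounds, is whether the position also tolerates a carboxylic acid, a morpholine or an unsubstituted benzyl group on the same sulfur. Compound 2 has no number, so steps involving it cannot be read, and what separates its sulfur-linked group from those of compound 1 and compound 3 remains unsized.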